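Replacing benzyloxy with ethoxy in a small ether series

The source may report more compounds than this note shows. Statements on the series, on what has been measured and on what is new or still open speak of the compounds shown alone.

Values in a functional assay on J774.A1 cells (Mus musculus) for inhibition, read by Griess assay, with stated times of 1 h and 24 h (on this read-out higher numbers stand for weaker inhibition and lower numbers for stronger inhibition), for the measured compounds:
- compound 1 `CC(C)COc1ccccc1C1CC(=O)c2ccccc2O1` at 33200 nM
- compound 2 `CCCCOc1ccccc1C1CC(=O)c2ccccc2O1` at 47700 nM
- compound 3 `O=C1CC(c2ccccc2OCc2ccccc2)Oc2ccccc21` at 23200 nM

The step of a 1.4-fold lower number from compound 1 to compound 3 (0.16 log units; within the scatter) leaves compound 3 level with compound 1, while the step of a 2.1-fold lower number from compound 2 to compound 3 (0.31 log units; beyond the scatter) places it modestly on the lower side of compound 2. Compound 4 `CCOc1ccccc1C1CC(=O)c2ccccc2O1` is the next case, and methyl in place of phenyl on a saturated chain carbon bound to an oxygen on an aromatic ring is its difference from compound 3, which also reads benzyloxy to ethoxy.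

All three measured steps bear on this change. The step of a 1.4-fold higher number from compound 1 to compound 2 (0.16 log units; within the scatter) does not separate the two saturated chains, and compound 4 likewise carries a saturated chain in place of the ring. Its number is therefore expected to lie near those of compound 1 and compound 2, with only a small move upward that may not clear the scatter. The expected step is a 1.7-fold higher number from compound 3 to compound 4 (0.24 log units; within the scatter) on this evidence. The estimate for compound 4 is 40000 nM with an expected range from 20000 nM to 80000 nM around it.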

Compound 4, half-maximal inhibitory concentration: 38800 nM
Compound 4: the middle estimate sits 1.0-fold (0.01 log units) above what was measured, and the stated range covers the measured number.
By their numbers in this assay, from the lowest: compounds 3, 1, 4 and 2 (each within the scatter of the next, the first and the last beyond it).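

In this assay the ethoxy compound reads level with the benzyloxy compound (a 1.7-fold higher number from compound 3 to compound 4 (0.22 log units; within the scatter)), so on a saturated chain carbon bound to an oxygen on an aromatic ring, methyl in place of phenyl does not clear the scatter. Compound 4 also stands level with the two other saturated chains (a 1.2-fold lower number from compound 2 to compound 4 (0.09 log units; within the scatter); a 1.2-fold higher number from compound 1 to compound 4 (0.07 log units; within the scatter)), which leaves the step from compound 2 to compound 3 as the only one beyond the scatter, and ethyl, like the other chains, sits within the scatter of benzyl. No measurement at hand explains these readings.

As far as these compounds go, whether any group at this place can move the number well beyond the scatter remains open. A terminal amine, a carboxylic acid or a longer chain such as octyl would test this, and the present ethers give no forecast for them.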